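Dihydroxyphenyl swap from compound 3 to compound 4

The source may hold more compounds than are shown below. What is called first, only, known or untested is meant among the compounds shown, and "the series" means these compounds.

Working notes on the series, read in an ADME assay on BJ cells (Homo sapiens) for cytotoxicity, read by MTT assay, with a stated time of 72 h; a lower number here means a stronger inhibitor, a higher number a weaker inhibitor. Compound 1 (`Oc1ccc(CNc2ncnc3c2ncn3C2CCCCO2)cc1`) gives > 100000 nM, a limit of the assay and not a number. Compound 2 (`COc1ccccc1CNc1ncnc2c1ncn2C1CCCCO1`) gives > 100000 nM, which is also a limit. For the measured compounds named here, compound 3 (`Oc1cccc(CNc2ncnc3c2ncn3C2CCCCO2)c1O`) gives 63300 nM, the only actual number so far. Its standing against compound 1 and compound 2 is known only through limits.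

Next is compound 4 (`Oc1cc(O)cc(CNc2ncnc3c2ncn3C2CCCCO2)c1`), which has the same atoms as compound 3, joined differently: 3,5-dihydroxyphenyl in place of 2,3-dihydroxyphenyl on a saturated chain carbon bound to a nitrogen on an aromatic ring. Going by the values given here, no measured step covers this exact exchange. The nearest evidence comes from changes at the same place, on a saturated chain carbon bound to a nitrogen on an aromatic ring. These are an at least 1.5-fold lower number from compound 1 to compound 3 (0.19 log units; that floor lies within the scatter) and an at least 1.5-fold lower number from compound 2 to compound 3 (0.19 log units; that floor lies within the scatter). Both are bounded by the limit of > 100000 nM in this assay, at which 2 of the 3 values shown sit, so they give floors and not sizes, and a step that the two limits leave unreadable from compound 1 to compound 2 adds nothing further.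

With compound 3 as the anchor at 63300 nM, no step beyond the scatter is expected in this assay. The expected step is a 1.3-fold higher number from compound 3 to compound 4 (0.10 log units; within the scatter). For compound 4 the estimated value is 80000 nM, with an expected range of 35000 nM to 180000 nM. A report as a limit remains a real possibility.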

Compound 4, half-maximal inhibitory concentration: > 100000 nM
Compound 4 gave a limit, no number; the forecaster's own chance of this, stated with the estimate: 50%; at least 1.2-fold (0.09 log units) between middle value and limit.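

In this assay, the same atoms joined differently, with 3,5-dihydroxyphenyl on a saturated chain carbon bound to a nitrogen on an aromatic ring, give an at least 1.5-fold higher number from compound 3 to compound 4 (0.19 log units; that floor lies within the scatter). For the compounds shown here, this is the first exchange at this place that keeps the group's composition and changes only how its atoms are joined, yet the result is a floor and does not show that the arrangement of the hydroxyl groups matters, and compound 3 remains the only compound with an actual number. The steps to compound 4 from compound 1 and from compound 2 cannot be read, and the true size of any step at this place stays hidden because the values gather at the upper end of the assay: the limit of > 100000 nM in this assay, at which 3 of the 4 values shown sit.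

Still open is whether any change at this place moves the number in this assay beyond the scatter, as the groups shown carry only hydroxyl and methoxy substituents on the phenyl ring. A carboxylic acid or an amine on that ring, or a longer chain in place of the saturated chain carbon, would put this question to a different kind of group.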